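This account rests on a few compounds, and the source may have more. Where it says the series, first, only, none or still open, it means among the compounds named here.

Working notes on the cytotoxicity series.

Of the compounds shown here, three sharing the aminosugar-bearing core have been read in an ADME assay on cells (Homo sapiens) for cytotoxicity, read by polymerase chain reaction, with a stated time of 3 days; on this read-out higher numbers stand for lower toxicity in this test and lower numbers for higher toxicity in this test. Compound 1 `Nc1nc(Cl)c(-c2nc3ccccc3o2)c(N[C@@H]2C[C@H](CO)[C@@H](O)[C@H]2O)n1` gives 12000 nM. Compound 2 `CCOc1ccc2nc(-c3c(Cl)nc(N)nc3N[C@@H]3C[C@H](CO)[C@@H](O)[C@H]3O)sc2c1` returns only the limit of the assay, > 25000 nM. Compound 3 `CNc1nc(C)c(-c2nc3ccccc3s2)c(N[C@@H]2C[C@H](CO)[C@@H](O)[C@H]2O)n1` likewise returns only a limit, > 25000 nM. For the measured compounds named here, no pair of these differs in a single place, so no step between measured compounds can be counted; what the three values show is that two of them sit at the limit of > 25000 nM in this assay, at which 2 of the 3 values shown sit, while compound 1 alone gives a number.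

Compound 4 `Cc1nc(NCC2CCC2)nc(N[C@@H]2C[C@H](CO)[C@@H](O)[C@H]2O)c1-c1nc2ccccc2s1` is not yet measured in this assay. It is reached from compound 3 by cyclobutyl in place of hydrogen on a saturated chain carbon bound to a nitrogen on an aromatic ring. With compound 3 itself at a limit, the step from compound 3 to compound 4 cannot be read as a direction at all; the expectation is for no movement beyond the scatter, a step that the limit leaves unreadable from compound 3 to compound 4, with the value of compound 4 expected again to land at or near the limit. Compound 4 is therefore estimated at 30000 nM, ranging from 10000 nM to 80000 nM.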

Compound 4, half-maximal cytotoxic concentration: > 25000 nM
Compound 4: a limit, no number (the forecaster's own chance of this, stated with the estimate: 70%); the middle value does not contradict the limit.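

Compound 3 and compound 4 each return only a limit, and no step can be read between them: the limit of > 25000 nM in this assay, at which 3 of the 4 values shown sit. The compounds shown leave open whether cyclobutyl in place of hydrogen at this place changes the read-out at all.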